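Lengthening the hydroxyalkyl chain by one carbon

This account rests on a few compounds, and the source may have more. Where it says the series, first, only, none or still open, it means among the compounds named here.

Measured so far:
Compound 1 `CCC(CC)(c1ccc(OS(=O)(=O)c2ccc(C)cc2)c(C)c1)c1ccc(OCC(O)C(C)(C)C)c(OCC(O)C(C)(C)C)c1`: 43%
Compound 2 `CCC(CC)(c1ccc(OCCCCCCO)c(C)c1)c1ccc(OCC(O)C(C)(C)C)c(OCC(O)C(C)(C)C)c1`: 52%

In an assay on cells for binding affinity to vitamin D3 receptor (Homo sapiens), read by fluorescence, tested at 1 uM (a lower number here means less inhibition, a higher number more inhibition at the concentration tested (going by the name of the read-out)), compound 1 gives 43% and compound 2 gives 52%. Compound 2 stands at the top of these two numbers, yet a number 9 percentage points higher from compound 1 to compound 2 (within the scatter) lies within the scatter, so the two cannot be told apart. Compound 3 `CCC(CC)(c1ccc(OCCCCCCCO)c(C)c1)c1ccc(OCC(O)C(C)(C)C)c(OCC(O)C(C)(C)C)c1` differs from compound 2 by hydroxymethyl in place of hydroxy on a saturated chain carbon, six bonds along the chain from an oxygen on an aromatic ring. Among the measured compounds shown here, the only measured step that bears on this change is the one at the same oxygen on an aromatic ring, and it stayed within the scatter. No step beyond the scatter is therefore expected, and compound 3 is estimated at 52% (range 38% to 66%), an expected step of no change at the digits printed from compound 2 to compound 3 (within the scatter).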

Compound 3, a percentage reported as inhibition, at one concentration (the size of the read-out at that concentration, not a potency): 5%
Estimate against measurement, compound 3: 47 percentage points above; measured number below the stated range.
By their numbers in this assay, from the lowest: compound 3; then compounds 1 and 2 (each within the scatter of the next).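

In this assay the end of this chain proves sensitive: hydroxymethyl in place of hydroxy brings a number 47 percentage points lower from compound 2 to compound 3 (beyond the scatter) while the earlier change at the oxygen on an aromatic ring stayed within the scatter. Set against the (4-methylphenyl)sulfonyl group, 7-hydroxyheptyl also brings a number 38 percentage points lower from compound 1 to compound 3 (beyond the scatter) and so differs from 6-hydroxyhexyl, whose step stayed within the scatter. Nothing available explains this drop. Still open, going by these compounds, is whether a longer chain stays this low, and whether an amine or a carboxylic acid in place of the end hydroxy would bring the number back.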